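This account rests on a few compounds, and the source may have more. Where it says the series, first, only, none or still open, it means among the compounds named here.

In an ADME assay on BaF3 cells (Mus musculus) for cytotoxicity, read by CellTiter-Glo and CCK-8 assay, with a stated time of 72 h (a higher number here means a weaker inhibitor of growth, a lower number a stronger inhibitor of growth), compound 1 (`C=CC(=O)N(CCN(C)C)Cc1ccc(C(=O)Nc2ccc(C)c(Nc3nccc(-c4cccnc4)n3)c2)cc1`) gives > 10000 nM as its reading, which is a limit of the assay and not a number. Compound 2 (`Cc1ccc(NC(=O)c2ccc(CN(CCN(C)C)C(=O)C(C)(C)C)cc2)cc1Nc1nccc(-c2cccnc2)n1`) gives > 10000 nM as its reading, again only a limit. Compound 2 therefore has no number of its own (the limit of > 10000 nM in this assay, at which 2 of the 2 values shown sit) and can be placed no more closely than that. Compound 3 (`Cc1ccc(NC(=O)c2ccc(CN(CCN(C)C)C(=O)CN(C)C)cc2)cc1Nc1nccc(-c2cccnc2)n1`) keeps the rest of compound 2 and carries (dimethylamino)methyl in place of tert-butyl on a carbonyl carbon. Going by the values given here, the only measured step at that carbonyl carbon (a step that the two limits leave unreadable from compound 1 to compound 2) offers no size to carry over. No step beyond the scatter is therefore expected in this assay and no direction can be given. The expected step (a number no higher from compound 2 to compound 3 (the limit leaves the size open)) is estimated from the limit of compound 2 alone. For compound 3 the estimated value is 10000 nM with an expected range from 3000 nM to 20000 nM and the reading may well be only a limit again.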

Compound 3, concentration for 50% growth inhibition: > 10000 nM
Compound 3: no number, only a limit; the forecaster's own chance of this, stated with the estimate: 80%; the middle value lies on the limit itself.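

No step can be read among compound 1, compound 2 and compound 3, whose readings are all limits and not numbers: the limit of > 10000 nM in this assay, at which 3 of the 3 values shown sit.

The compounds shown leave open how strongly any of the three inhibits growth, and whether the group on the carbonyl carbon alters that at all.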